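Chain Length and Amine Change in a Dinitrile Series

The source may report more compounds than this note shows. Statements on the series, on what has been measured and on what is new or still open speak of the compounds shown alone.

Measured compounds:
Compound 1 `CCN(CC)CCn1c(N)c(-c2nc3ccccc3[nH]2)c2nc(C#N)c(C#N)nc21` gives 2490 nM in a functional assay on K562 cells (Homo sapiens) for antiproliferative activity, read by MTT assay, with a stated time of 48 h; a lower number here means a stronger inhibitor, a higher number a weaker inhibitor.
Compound 2 `CN(C)CCCn1c(N)c(-c2nc3ccccc3[nH]2)c2nc(C#N)c(C#N)nc21` gives 1730 nM in this assay.
Compound 3 `CCN(CC)CCCn1c(N)c(-c2nc3cc(Cl)ccc3[nH]2)c2nc(C#N)c(C#N)nc21` gives 4830 nM in this assay.

Compound 1 and compound 2 share a core and differ in one place: (dimethylamino)methyl in place of diethylamino on a saturated chain carbon, two bonds along the chain from an aromatic nitrogen. That change made a step of a 1.4-fold lower number from compound 1 to compound 2 (0.16 log units; within the scatter), so the two numbers cannot be told apart with confidence. Compound 3 carries a core that differs from that of compound 1 in more than one place; the difference between the two cores is not broken down here. What the values show is that the number for compound 3 lies close to that of compound 1 and higher than that of compound 2.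

Compound 4 `CN(C)CCCCn1c(N)c(-c2nc3cc(Cl)ccc3[nH]2)c2nc(C#N)c(C#N)nc21` has not yet been measured. It differs from compound 3 by (dimethylamino)methyl in place of diethylamino on a saturated chain carbon, three bonds along the chain from an aromatic nitrogen. This is the same kind of change as that between compound 1 and compound 2, but the place is not the same word for word: there the amine sits two bonds along the chain from an aromatic nitrogen, here three bonds along. Because the matched step a 1.4-fold lower number from compound 1 to compound 2 (0.16 log units; within the scatter) stayed within the scatter, a step of similar small size is expected from compound 3 to compound 4 in this assay, namely a 1.4-fold lower number from compound 3 to compound 4 (0.14 log units; within the scatter). The longer chain in compound 4 adds some uncertainty, which widens the range. Compound 4 is therefore estimated to give about 3500 nM in this assay, expected to fall between 1500 nM and 8000 nM.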

Compound 4, half-maximal inhibitory concentration: 1930 nM
For compound 4 the middle estimate is 1.8-fold (0.26 log units) above the measured one; the measured number falls inside the stated range.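

The change from 3-(diethylamino)propyl to 4-(dimethylamino)butyl gave a 2.5-fold lower number from compound 3 to compound 4 (0.40 log units; beyond the scatter) in this assay, so on this core the lower number can be told apart from ordinary assay noise. Set beside the matching change from 2-(diethylamino)ethyl to 3-(dimethylamino)propyl on the other core, the step points the same way, and the two steps cannot be said to differ in size: the same change on two cores in this assay, a 1.4-fold lower number (0.16 log units; within the scatter) from compound 1 to compound 2 and a 2.5-fold lower number (0.40 log units; beyond the scatter) from compound 3 to compound 4, 1.7-fold (0.24 log units) apart, within the scatter of two such steps. Going by these compounds alone, this fits the change carrying over from one core to the other, but it rests on only two pairs, only one of those steps is beyond the scatter, and the place of the change is not identical in the two pairs, so it shows no general rule for the series and does not separate the effect of the amine from that of the longer chain.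

From the compounds shown here alone, a 3-(dimethylamino)propyl chain on the core of compound 3 would pull these two parts of the change apart, and what it would give remains open. Also open, going by these compounds, is how the same core would respond to a cyclic amine such as morpholine or piperidine in place of the dimethylamino group, or to a chain longer than butyl.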